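The source may report more compounds than this note shows. Statements on the series, on what has been measured and on what is new or still open speak of the compounds shown alone.

Compound 2, `N#Cc1cccc(-c2ccc(CN(CCN3CCCC3)C(=O)Nc3ccc(F)c(Cl)c3)cc2)c1`, is one of two compounds already tested. In a functional assay for antagonist activity at melanin-concentrating hormone receptor 2 (Homo sapiens) (a higher number here means a weaker inhibitor, a lower number a stronger inhibitor), compound 2 gives > 3000 nM, and this value is a limit of the assay rather than a measured number. Its near relative compound 1, `N#Cc1cccc(-c2ccc(CN(CCN3CCCC3)C(=O)Nc3cc(Cl)cc(Cl)c3)cc2)c1`, differs from it only in the aryl group on the amide-type nitrogen. In this assay compound 1 gives > 3000 nM, which is likewise a limit of the assay. The step that the two limits leave unreadable from compound 1 to compound 2 therefore cannot be sized, and the two measurements share (the limit of > 3000 nM in this assay, at which 2 of the 2 values shown sit).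

Compound 3, `N#Cc1cccc(-c2ccc(CN(CCN3CCCC3)C(=O)Nc3ccc(F)c(C(F)(F)F)c3)cc2)c1`, has not yet been measured. It differs from compound 2 by trifluoromethyl in place of chloro on an aromatic carbon. Within the data shown here, no measured step bears on this particular change; the only step between measured compounds is unreadable, so no size can be carried over from it. On that basis a step of no readable size in this assay is expected, a step that the limit leaves unreadable from compound 2 to compound 3. For compound 3 in this assay a value of 5000 nM is estimated, within a range from 1500 nM to 30000 nM, with a considerable chance that the assay again reports only a limit.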

Compound 3, inhibition constant: > 3000 nM
Compound 3 ended at the assay's limit; the forecaster's own chance of this, stated with the estimate: 70%; the middle value lies beyond the limit too.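

Compound 3 gives > 3000 nM in this assay, and this value is a limit of the assay. Among these compounds, no step among compound 1, compound 2 and compound 3 can be read, because all three stop at the same point: the limit of > 3000 nM in this assay, at which 3 of the 3 values shown sit. The compounds shown leave open how much, if at all, these aryl groups on the amide-type nitrogen differ in inhibition.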